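A few compounds are considered here, and "the series" means these few. Any claim that something is new, unique, unknown or untested is made for them only; others in the source may bear on it.

Compound 1 `Clc1cccc(-c2cnc(Nc3ccccc3)nc2-c2ccccc2)c1` and compound 2 `Clc1cccc(-c2cnc(NC3CCCC3)nc2-c2ccccc2)c1` share one core and differ only at the nitrogen on the aromatic ring. In an assay on CHO cells for displacement of a labelled ligand from adenosine receptor A1 (Homo sapiens), read by scintillation counting, with a stated time of 1 h, tested at 1 uM (on this read-out higher numbers stand for more inhibition at the one concentration tested (going by the name of the read-out) and lower numbers for less inhibition), compound 1 gives 34%. For compound 2 this assay reports only a limit, > 80%, and no number. The step of a number at least 46 percentage points higher from compound 1 to compound 2 (beyond the scatter) is therefore large, and compound 2 sits at the ceiling of this assay, as noted in the limit of > 80% in this assay, at which 1 of the 2 values shown sits. Compound 3 `OCCCNc1ncc(-c2cccc(Cl)c2)c(-c2ccccc2)n1` carries the change (3-hydroxypropyl in place of cyclopentyl on a nitrogen on an aromatic ring), that is cyclopentylamino to (3-hydroxypropyl)amino. Among the measured compounds shown here, no measured step concerns this exchange; the single measured step, phenyl to cyclopentyl, ran upward and says nothing about a 3-hydroxypropyl chain. The expected step of a number at least 20 percentage points lower from compound 2 to compound 3 (beyond the scatter) is accordingly uncertain, a downward move being held somewhat more likely than none beyond the scatter. For compound 3 the estimate in this assay is 60%, within 25% to 90%.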

Compound 3, a percentage reported as inhibition, at one concentration (the size of the read-out at that concentration, not a potency): > 80%
Compound 3: a limit, no number; the forecaster's own chance of this, stated with the estimate: 30%; middle value at least 20 percentage points from the limit.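

The step of a number at least 46 percentage points higher from compound 1 to compound 3 (beyond the scatter) in this assay replaces phenyl on the nitrogen with 3-hydroxypropyl, and it points the same way as the step of a number at least 46 percentage points higher from compound 1 to compound 2 (beyond the scatter). Among these compounds, a ring on this nitrogen is therefore not required for a read-out beyond that of compound 1, as the open chain of compound 3 shows. Compound 2 and compound 3 are both reported only as limits, the step between them cannot be read, and no order can be given for the pair: the limit of > 80% in this assay, at which 2 of the 3 values shown sit.

Going by these compounds, how cyclopentyl and 3-hydroxypropyl compare at this nitrogen stays open. Also open, on these data alone, is how the read-out in this assay would respond to a longer chain, or to a terminal amine or carboxylic acid in place of the hydroxyl.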